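Replacing the Amino Group With a Propanoyloxymethyl Ester

The compounds below may be only part of what the source reports. "The series", "measured", "known", "first", "only" and "open" are said of these compounds alone.

The measured compounds, all tested in a functional assay on HeLa cells (Homo sapiens) for cytotoxicity, read by neutral red uptake, with a stated time of 3 days; a higher number here means a weaker inhibitor, a lower number a stronger inhibitor:
Compound 1, `Nc1ccc(-c2cc(=O)c3c(N)c(F)cc(F)c3o2)cc1F`, gives > 100000 nM, which is a limit of the assay and not a number.
Compound 2, `CCc1c(F)c(N)c2c(=O)cc(-c3ccc(N)c(F)c3)oc2c1F`, gives > 100000 nM, again a limit of the assay.
Compound 3, `Nc1ccc(-c2cc(=O)c3c(N)c(F)c(N)c(F)c3o2)cc1F`, gives 19000 nM.

Within the data shown here, compound 3 therefore stands alone: it carries the only value that is a number, while the other two compounds sit at the limit of > 100000 nM in this assay, at which 2 of the 3 values shown sit. Compound 4, `CCC(=O)OCc1c(F)c(N)c2c(=O)cc(-c3ccc(N)c(F)c3)oc2c1F`, has not yet been measured. It differs from compound 3 in one place: (propanoyloxy)methyl in place of amino on an aromatic carbon.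

Among the measured compounds shown here, two measured steps bear on this change, both in the opposite direction, since each brings the amino group in rather than taking it away. The step of an at least 5.2-fold lower number from compound 1 to compound 3 (0.72 log units; beyond the scatter) and the step of an at least 5.2-fold lower number from compound 2 to compound 3 (0.72 log units; beyond the scatter) both lowered the number at least modestly once the amino group was present. Compound 4 removes that amino group and puts a carbon-linked ester in its place, so the expected step of a 4.2-fold higher number from compound 3 to compound 4 (0.62 log units; beyond the scatter) is a higher number, possibly back toward the limit. For compound 4 the estimate in this assay is 80000 nM, with a range from 20000 nM to 300000 nM.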

Compound 4, half-maximal inhibitory concentration: 69000 nM
Beside the measured number, compound 4's estimate is 1.2-fold (0.06 log units) above it; the measured number falls inside the stated range.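

In this assay, among these compounds, putting (propanoyloxy)methyl in place of amino on the aromatic carbon ortho to two fluoro groups gives a 3.6-fold higher number from compound 3 to compound 4 (0.56 log units; beyond the scatter), so the amino group of compound 3 is not the only group at this position that brings a readable number, although the ester gives a higher one. Set against the two compounds without amino there, the new steps are an at least 1.4-fold lower number from compound 1 to compound 4 (0.16 log units; that floor lies within the scatter) and an at least 1.4-fold lower number from compound 2 to compound 4 (0.16 log units; that floor lies within the scatter), so the ester cannot yet be separated from hydrogen or ethyl at this position. Compound 1 and compound 2 each give a limit and not a number: the limit of > 100000 nM in this assay, at which 2 of the 4 values shown sit.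

From the compounds shown here alone, it remains open whether the ester carbonyl matters at this position or whether any chain of similar size would serve, and a hydroxymethyl, methoxymethyl or aminomethyl group here would help to separate those readings. Going by these compounds, it also remains open whether any group can bring the number lower than the amino group of compound 3 does, a question that a methylamino or hydroxyl group at the same position would begin to test.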